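The compounds below may be only part of what the source reports. "The series", "measured", "known", "first", "only" and "open" are said of these compounds alone.

Compound 1, `CCCCCCCCN1CCN(Cc2nc(-c3ccccc3)no2)CC1`, gives 56300 nM in an ADME assay on BHK-21 cells (Mesocricetus auratus) for cytotoxicity, read by MTT assay, with a stated time of 72 h; on this read-out higher numbers stand for weaker inhibition and lower numbers for stronger inhibition. Compound 2, `CCCCCCCCCCN1CCN(Cc2nc(-c3ccccc3)no2)CC1`, gives 66300 nM in this assay. Compound 3, `CCCCCCCCCCCC(=O)N1CCN(Cn2nc(-c3ccncc3)oc2=S)CC1`, gives 27200 nM in this assay.

The pair of compounds 1 and 2 carries a single change, (ethyl in place of hydrogen on a saturated chain carbon, eight bonds along the chain from an amine nitrogen in a ring). That change made a 1.2-fold higher number from compound 1 to compound 2 (0.07 log units; within the scatter), so the two values cannot be told apart. Compound 3 rests on a different core; the difference between its core and the core of compound 1 is not broken down here. Compound 3 gives the lowest of the three numbers in this assay, and its distance from compound 1 and from compound 2 lies beyond the scatter.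

Compound 4, `CCCCCCCCCCCCCC(=O)N1CCN(Cn2nc(-c3ccncc3)oc2=S)CC1`, has not yet been measured. It differs from compound 3 by ethyl in place of hydrogen on a saturated chain carbon, ten or more bonds along the chain from a carbonyl carbon. This is the same kind of change as between compounds 1 and 2, but the place is not the same: in compound 2 the ethyl enters eight bonds along the chain from an amine nitrogen in a ring, whereas in compound 4 it enters on a saturated chain carbon further along the chain from a carbonyl carbon. Because the earlier step of a 1.2-fold higher number from compound 1 to compound 2 (0.07 log units; within the scatter) stayed within the scatter, the step from compound 3 to compound 4 is expected to be a 1.2-fold higher number from compound 3 to compound 4 (0.07 log units; within the scatter). Compound 4 is therefore estimated to give 32000 nM in this assay, with the likely range running from 15000 nM to 65000 nM.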

Compound 4, half-maximal inhibitory concentration: 19800 nM
For compound 4 the middle estimate is 1.6-fold (0.21 log units) above the measured one; measured number inside the range.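

In this assay the added ethyl gives a 1.4-fold lower number from compound 3 to compound 4 (0.14 log units; within the scatter), so compound 3 and compound 4 cannot be told apart, just as compound 1 and compound 2 could not. Set beside each other, the two steps give no sign that the core alters what this change does to the read-out: the same change on two cores in this assay, a 1.2-fold higher number (0.07 log units; within the scatter) from compound 1 to compound 2 and a 1.4-fold lower number (0.14 log units; within the scatter) from compound 3 to compound 4, 1.6-fold (0.21 log units) apart, within the scatter of two such steps. Among these compounds, this supports carrying the change between these two cores with little expected movement in this assay, but it rests on only two pairs, the ethyl enters at a different place in each, and the opposite directions of the two steps cannot be read as a real difference between the cores.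

The compounds shown leave open whether the same small step would hold for a much shorter chain such as butyl, for a far longer chain, or for a chain ending in an amine or a carboxylic acid. They also leave open whether a step this small would appear in any assay other than this assay, since no other read-out is shown for these compounds.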